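The compounds below may be only part of what the source reports. "The series", "measured", "known", "first", "only" and "open" are said of these compounds alone.

Working notes on the series. The core shared by these compounds is seen in compound 1 `COc1cc(C(=O)c2sc3ccccc3c2-c2ccc(F)cc2)cc(OC)c1OC`, compound 2 `COc1cc(C(=O)c2sc3ccccc3c2-c2ccc(C)cc2)cc(OC)c1OC` and compound 3 `COc1ccc(OC)c(-c2c(C(=O)c3cc(OC)c(OC)c(OC)c3)sc3ccccc23)c1`, which differ only in the aryl group on the five-membered ring. In a functional assay on K562 cells (Homo sapiens) for antiproliferative activity, read by MTT assay, with a stated time of 72 h (a lower number here means a stronger inhibitor, a higher number a weaker inhibitor), compound 1 gives 2100 nM. Compound 2 gives 3500 nM in this assay, and the step of a 1.7-fold higher number from compound 1 to compound 2 (0.22 log units; within the scatter) leaves the two within the scatter of each other, so no order between compound 1 and compound 2 can be read. For compound 3 this assay reports only a limit, > 10000 nM; of the three values shown, one sits at this limit (the limit of > 10000 nM in this assay, at which 1 of the 3 values shown sits). The step of an at least 2.8-fold higher number from compound 2 to compound 3 (0.45 log units; beyond the scatter) is the one clear movement seen so far, as is an at least 4.7-fold higher number from compound 1 to compound 3 (0.67 log units; beyond the scatter).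

Compound 4 `COc1cc(C(=O)c2sc3ccccc3c2Nc2ccc(C)cc2)cc(OC)c1OC` keeps the 4-methylphenyl of compound 2 but changes the link: (4-methylphenyl)amino in place of 4-methylphenyl on an aromatic carbon. Going by the values given here, no measured step changes the linking atom between the core and the aryl group, so the two aryl-ring steps give no direct guide. The expectation for compound 4 is therefore a step of a 1.4-fold higher number from compound 2 to compound 4 (0.15 log units; within the scatter), with wide uncertainty in either direction. Compound 4 is estimated at 5000 nM in this assay, within a range of 1500 nM to 20000 nM.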

Compound 4, half-maximal inhibitory concentration: 1600 nM
Estimate against measurement, compound 4: 3.1-fold (0.49 log units) above, and the stated range covers the measured number.
By their numbers in this assay, from the lowest: compounds 4, 1 and 2 (each within the scatter of the next, the first and the last beyond it). At a limit, above all of these: compound 3.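

Among the compounds shown, this is the only change of the link at this position, two ring bonds from the ring sulfur, and with the 4-methylphenyl kept the (4-methylphenyl)amino group gives a modest gain in this assay: a 2.2-fold lower number from compound 2 to compound 4 (0.34 log units; beyond the scatter). The gain does not carry over to the comparison with the 4-fluorophenyl group, where a 1.3-fold lower number from compound 1 to compound 4 (0.12 log units; within the scatter) leaves no order to be read, so the new link is set apart from the 4-methylphenyl of compound 2 but not from the 4-fluorophenyl of compound 1. The largest movement, an at least 6.2-fold lower number from compound 3 to compound 4 (0.79 log units; beyond the scatter), shows that an aryl group reached through the amino link can lie well clear of compound 3, but that step rests on a limit for compound 3 and not on a number: the limit of > 10000 nM in this assay, at which 1 of the 4 values shown sits.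

As far as these compounds go, whether the step from the direct link belongs to the amine hydrogen or to the added linking atom stays open, and an N-methylamino link, an ether oxygen or a thioether at the same position would separate the two. Also open, from the compounds shown here alone, is how the amino link behaves with other aryl groups, such as (4-fluorophenyl)amino or (2,5-dimethoxyphenyl)amino, each of which would pair directly with a compound already in hand.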